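A Fourth Analogue in the Whole-Animal Inhibition Series

A few compounds are considered here, and "the series" means these few. Any claim that something is new, unique, unknown or untested is made for them only; others in the source may bear on it.

Compound 1 `CC1CC/C(=N\Nc2ccccc2Cl)c2ncc(C(=O)O)c(=O)n21`: in a functional assay on the whole organism for inhibition, with Rattus norvegicus as the target (a higher number here means that more compound is needed for the effect, a lower number that less compound is needed), compound 1 gives > 1000 umol/kg, a limit.
Compound 2 `CC1CC/C(=N\Nc2cccc(Cl)c2)c2ncc(C(=O)O)c(=O)n21`: in this assay compound 2 gives > 100 umol/kg, a limit.
Compound 3 `CC1CC/C(=N\Nc2ccc(O)cc2)c2ncc(C(=O)O)c(=O)n21`: in this assay compound 3 gives > 100 umol/kg, a limit.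

None of the three measured compounds has a numerical result; each reached only a limit. Compound 3 stands at the limit of > 100 umol/kg in this assay, at which 2 of the 3 values shown sit, and compound 2 sits at the same limit, while compound 1 sits at the limit of > 1000 umol/kg in this assay, at which 1 of the 3 values shown sits. The steps a step that the two limits leave unreadable from compound 1 to compound 2, a step that the two limits leave unreadable from compound 1 to compound 3 and a step that the two limits leave unreadable from compound 2 to compound 3 are therefore all unreadable.

Compound 4 `Cc1ccccc1N/N=C1\CCC(C)n2c1ncc(C(=O)O)c2=O` differs from compound 3 by 2-methylphenyl in place of 4-hydroxyphenyl on an amine nitrogen. Among the measured compounds shown here, no measured step gives the size of this change, since every value in this assay is a limit. Compound 1 carries 2-chlorophenyl and compound 4 carries 2-methylphenyl; compound 1 gave only a limit. Compound 4 is therefore expected to give a limit as well, the estimated step being a step that the limit leaves unreadable from compound 3 to compound 4. The expected value for compound 4 is 1000 umol/kg, with a range from 100 umol/kg to 10000 umol/kg.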

Compound 4, dose for 50% inhibition: > 100 umol/kg
Compound 4: no number, only a limit (the forecaster's own chance of this, stated with the estimate: 85%); the middle value does not contradict the limit.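

In this assay compound 4 gives > 100 umol/kg, a limit, so its steps from compound 1, compound 2 and compound 3 cannot be read. The four compounds shown, none with a numerical result, leave open whether the group on the amine nitrogen changes the dose needed at all.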